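Methyl for chloro on the anilino ring of compound 3

The source may report more compounds than this note shows. Statements on the series, on what has been measured and on what is new or still open speak of the compounds shown alone.

Among the three measured compounds, compound 3 `Clc1ccc(NCc2cn(-c3ccccc3)nc2-c2ccc(Cl)cc2)cc1` gives the lowest number in a functional assay on MCF7 cells (Homo sapiens) for antiproliferative activity, read by MTT assay, with a stated time of 48 h (on this read-out lower numbers stand for stronger inhibition and higher numbers for weaker inhibition), at 2280 nM. Compound 1 `COc1ccc(-c2nn(-c3ccccc3)cc2CNc2ccc(F)cc2)cc1` gives 5980 nM, and compound 2 `COc1ccc(-c2nn(-c3ccccc3)cc2CNc2ccc(C)cc2)cc1` gives 8160 nM; both numbers lie beyond the scatter above that of compound 3. Compound 4 `Cc1ccc(NCc2cn(-c3ccccc3)nc2-c2ccc(Cl)cc2)cc1` differs from compound 3 by methyl in place of chloro on an aromatic carbon, on the (4-chlorophenyl)amino group, which becomes (4-methylphenyl)amino.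

Among the compounds with values here, no measured pair shows exactly this change. The nearest comparison is the step of a 1.4-fold higher number from compound 1 to compound 2 (0.13 log units; within the scatter), where a methyl replaces a fluoro, not a chloro, at the same place; that step stayed within the scatter. Taking it as the only guide, a modest rise in the number from compound 3 to compound 4 is expected in this assay, possibly within the scatter and at most a little beyond it, which corresponds to an expected step of a 1.4-fold higher number from compound 3 to compound 4 (0.15 log units; within the scatter). Compound 4 is therefore estimated at 3200 nM, with a range from 1500 nM to 7000 nM.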

Compound 4, half-maximal inhibitory concentration: 3110 nM
Beside the measured number, compound 4's estimate is 1.0-fold (0.01 log units) above it, and the stated range covers the measured number.
By their numbers in this assay, from the lowest: compounds 3, 4, 1 and 2 (each within the scatter of the next, the first and the last beyond it).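

In this assay, methyl in place of chloro on the (4-chlorophenyl)amino group gives a 1.4-fold higher number from compound 3 to compound 4 (0.13 log units; within the scatter), so this position tolerates the change without a shift beyond the scatter. Together with the earlier methyl-for-fluoro step, this makes two exchanges at this position that stay within the scatter, with the rest of each molecule held constant. With the methyl kept on the anilino ring, chloro in place of methoxy on an aromatic carbon gives a 2.6-fold lower number from compound 2 to compound 4 (0.42 log units; beyond the scatter), so the change elsewhere in the molecule moves the number further than either change at this position.

As far as these compounds go, whether a carboxylic acid or an amine at this position would also leave the number within the scatter remains open. Nothing given here accounts for the size of either step.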